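Replacing the lactam of compound 2 with methyl(phenyl)amino

The source may hold more compounds than are shown below. What is called first, only, known or untested is meant among the compounds shown, and "the series" means these compounds.

compound 1 `O=C1c2ccccc2CN1c1cnc(NCc2c(F)ccc3c2CCO3)n2cnnc12` gives 4000 nM
compound 2 `C[C@@H]1CC(=O)N(c2cnc(NCc3c(F)ccc4c3CCO4)n3cnnc23)C1` gives 130000 nM

In a physicochemical assay for solubility, read by LC-MS, in phosphate buffer, with a stated time of 24 h, at pH 7.4 (on this read-out lower numbers stand for lower solubility and higher numbers for higher solubility), compound 2 stands highest of the two (130000 nM). Compound 3 `CN(c1ccccc1)c1cnc(NCc2c(F)ccc3c2CCO3)n2cnnc12` has methyl(phenyl)amino in place of 4-methyl-2-oxopyrrolidin-1-yl on an aromatic carbon. For the measured compounds named here, the only measured step bearing on this (a 33-fold higher number from compound 1 to compound 2 (1.51 log units; beyond the scatter)) was large and beyond the scatter, and the group of compound 1 also holds a six-membered aromatic ring of carbon only. A large step to a lower number is therefore expected (a 26-fold lower number from compound 2 to compound 3 (1.41 log units; beyond the scatter)). For compound 3 the estimated value is 5000 nM (expected range 800 nM to 30000 nM).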

Compound 3, solubility: < 2000 nM
Compound 3 was reported as a limit; the forecaster's own chance of this, stated with the estimate: 5%; at least 2.5-fold (0.39 log units) between middle value and limit.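

Methyl(phenyl)amino in place of 4-methyl-2-oxopyrrolidin-1-yl on this aromatic carbon gives an at least 65-fold lower number from compound 2 to compound 3 (1.81 log units; beyond the scatter). In this assay compound 3 is a limit, not a number: the limit of < 2000 nM in this assay, at which 1 of the 3 values shown sits. Against compound 1 the change reads as an at least 2.0-fold lower number from compound 1 to compound 3 (0.30 log units; that floor lies within the scatter), so the two groups holding a six-membered aromatic ring of carbon only both read far lower than the 4-methyl-2-oxopyrrolidin-1-yl of compound 2, with or without the five-membered ring of compound 1.

Going by these compounds, the true number for compound 3 stays open, and so does the order of compound 1 and compound 3. Also open, on these data alone, is how a morpholine or a carboxylic acid would read on this carbon.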